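This account rests on a few compounds, and the source may have more. Where it says the series, first, only, none or still open, it means among the compounds named here.

Compound 1, whose structure is `COc1ccc(-c2cc(/C=C/C(=O)c3ccc(N)cc3)[nH]n2)cc1`, compound 2, with the structure `COc1ccc(-c2cc(/C=C/C(=O)c3ccc(N)cc3)[nH]n2)cc1OC`, and compound 3, with the structure `COc1cc(C(=O)/C=C/c2cc(-c3cc(OC)c(OC)c(OC)c3)n[nH]2)cc(OC)c1OC`, were all tested in a functional assay on COLO 205 cells (Homo sapiens) for cytotoxicity, read by sulforhodamine B assay, with a stated time of 48 h, tested at 1 uM; a lower number here means a stronger effect, a higher number a weaker effect of the compound at the concentration tested. In this assay compound 1 gives 100%, compound 2 gives 98%, and compound 3 gives 98%. The three numbers sit close together, and none of the gaps between them is larger than the usual scatter of such measurements, so no one of them can be called stronger or weaker than another.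

Compound 1 and compound 2 differ in one place: hydrogen in place of methoxy on an aromatic carbon. The step that goes with this change is a number 2 percentage points higher from compound 2 to compound 1 (within the scatter). How the core of compound 3 differs from the core of compound 2 is not broken down here.

Compound 4, with the structure `COc1ccc(-c2cc(/C=C/C(=O)c3cc(OC)c(OC)c(OC)c3)[nH]n2)cc1OC`, has not yet been measured. It comes from compound 3 by the change (hydrogen in place of methoxy on an aromatic carbon). For the measured compounds named here, this is the same kind of change as the one from compound 2 to compound 1, though not the same: around the place in compound 3 the position is also meta to a methoxy group, which is not so in compound 2. Since the earlier change left the read-out where it was, the step from compound 3 to compound 4 is expected to be a number 1 percentage points higher from compound 3 to compound 4 (within the scatter), again within the scatter. Compound 4 is therefore estimated to give 99%, most likely between 90% and 105%.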

Compound 4, a percentage reported as activity, at one concentration (the size of the read-out at that concentration, not a potency): 89%
Estimate against measurement, compound 4: 10 percentage points above; measured number outside the range, below it.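

In this assay, putting hydrogen in place of a methoxy group on an aromatic carbon gives a number 9 percentage points lower from compound 3 to compound 4 (within the scatter), and set beside the same change on the other core, the two steps cannot be told apart: the same change on two cores in this assay, a number 2 percentage points higher (within the scatter) from compound 2 to compound 1 and a number 9 percentage points lower (within the scatter) from compound 3 to compound 4, 11 percentage points apart, within the scatter of two such steps

So, across these two pairs, the change carries from one core to the other with no step that stands clear of the usual scatter, and no sign that the core decides the outcome. This does not show that the change is without effect throughout the series, or that the two cores respond alike in any finer sense, since the read-out comes from a single concentration and gives no potency, and two pairs are a small base for a rule.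

The compounds shown leave open what other groups at this place on the ring would do, for instance a hydroxyl, a fluorine or a carboxylic acid, or a longer chain such as ethoxy. They also leave open whether any such group, on either core, would give a step in this assay that stands beyond the scatter.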